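A few compounds are considered here, and "the series" means these few. Any claim that something is new, unique, unknown or untested is made for them only; others in the source may bear on it.

For the measured compounds named here, compound 1 `CC(C(=O)NCc1ccc(C(F)(F)F)nc1Nc1ccccc1)c1ccc(NS(C)(=O)=O)c(F)c1` is the only member of this set for which a number is reported: in a functional assay on CHO-K1 cells for antagonist activity at transient receptor potential cation channel subfamily V member 1 (Homo sapiens), read by FLIPR (a lower number here means a stronger inhibitor, a higher number a weaker inhibitor), compound 1 gives 59.6 nM. Going by the values given here, compound 2 `CC(C(=O)NCc1ccc(C(F)(F)F)nc1N1CCC(O)CC1)c1ccc(NS(C)(=O)=O)c(F)c1` is recorded in this assay as "not active" (no number reported), so no figure is attached to it and no step between it and compound 1 can be sized. Compound 3 `CC(C(=O)NCc1ccc(C(F)(F)F)nc1N1CCCCCC1)c1ccc(NS(C)(=O)=O)c(F)c1` has not yet been tested. It differs from compound 1 in one place: azepan-1-yl in place of anilino on an aromatic carbon. Compound 1 thus stands alone on the numbers shown, and the single other entry offers nothing to compare against. Among the compounds with values here, with no measured step to lean on, the expectation rests on the structural change itself and on the fact that the other entry, compound 2, is reported as "not active" (no number reported). Compound 3 is therefore expected to be the weaker inhibitor, by a step of a 25-fold higher number from compound 1 to compound 3 (1.40 log units; beyond the scatter) that goes well beyond the scatter. The value estimated for compound 3 is 1500 nM, within a range from 300 nM to 8000 nM, and there is a real chance that this assay returns only a limit for it.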

Compound 3, inhibition constant: 0.8 nM
Compound 3: middle estimate off by 1900-fold (3.27 log units), on the high side; the measured number lies below the stated range.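

In this assay, azepan-1-yl in place of anilino on this aromatic carbon gives a 75-fold lower number from compound 1 to compound 3 (1.87 log units; beyond the scatter), a large step that shows this position does not need an aromatic ring or the hydrogen-bond donor of anilino for strong inhibition. The two groups match in their count of heavy atoms, yet compound 2, which also carries a non-aromatic ring here, is recorded as not active, so a non-aromatic ring at this position is not enough on its own, and the step to compound 2 cannot be read. Nothing measured on these compounds accounts for the size of the change from anilino to azepan-1-yl.

The compounds shown leave open whether the difference between compound 3 and compound 2 lies in the size of the ring, in the hydroxyl group of compound 2, or in both. They also leave open how far the strong inhibition of compound 3 extends to other groups at this position, such as pyrrolidin-1-yl or an open-chain amine like diethylamino.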